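Bromo-anilide series: demethylation of the aryl ether

A few compounds are considered here, and "the series" means these few. Any claim that something is new, unique, unknown or untested is made for them only; others in the source may bear on it.

Compound 1 `COc1c(Br)cc(Br)cc1C(=O)Nc1ccccc1` is the reference point. In an assay for inhibition of HSP60/HSP10 (Homo sapiens), with a stated time of 60 min (a higher number here means a weaker inhibitor, a lower number a stronger inhibitor), compound 1 reaches only the assay limit, > 100000 nM, so its standing rests on a limit rather than a number. Compound 2 `COc1c(Br)cccc1C(=O)Nc1ccccc1` differs from it by hydrogen in place of bromo on an aromatic carbon. In this assay compound 2 also stops at the limit, > 100000 nM. Compound 3 `COc1ccc(Br)cc1C(=O)Nc1ccccc1` again carries hydrogen in place of bromo on an aromatic carbon. In this assay compound 3 likewise returns the limit, > 100000 nM. The step that the two limits leave unreadable from compound 1 to compound 2 and the step that the two limits leave unreadable from compound 1 to compound 3 therefore cannot be sized; all three values sit at the limit of > 100000 nM in this assay, at which 3 of the 3 values shown sit.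

Compound 4 `O=C(Nc1ccccc1)c1cc(Br)cc(Br)c1O` is the next member: hydrogen in place of methyl on an oxygen on an aromatic ring, which read one bond further out is methoxy to hydroxy. Among the compounds with values here, no measured step bears on this change, and the two steps that exist are both unreadable, so they give no direction for the step from compound 1 to compound 4. The expectation is that compound 4 will again return a limit, with the estimated step of an at least 1.2-fold lower number from compound 1 to compound 4 (0.09 log units; that floor lies within the scatter) carrying wide uncertainty. The estimate for compound 4 in this assay is 80000 nM, within a range from 15000 nM to 300000 nM.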

Compound 4, half-maximal inhibitory concentration: 63000 nM
Compound 4: the middle estimate sits 1.3-fold (0.10 log units) above what was measured; measured number inside the range.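

In this assay compound 4 gives 63000 nM as a readable number. Within the data shown here, this makes hydroxy at this place on the aromatic ring the first change to give anything other than the assay limit. The two hydrogen-for-bromo changes left the read-out at that limit, so the oxygen substituent is the only place shown where a change registers at all. Methoxy to hydroxy gives an at least 1.5-fold lower number from compound 1 to compound 4 (0.20 log units; that floor lies within the scatter) and only a floor on the step can be read, so the true size may be larger, but that floor alone does not set the pair apart. The remaining compounds give no number to compare with compound 4: the limit of > 100000 nM in this assay, at which 3 of the 4 values shown sit.

Still open, as far as these compounds go, is whether an amine or a carboxylic acid at the same place on the aromatic ring, or a longer chain on that oxygen, would also give a readable number. Also open is how much of the value of compound 4 depends on the two bromo groups, as the compounds shown pair hydroxy with only that one bromo pattern.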